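A Second Methyl on an Amide Already Silent in Cytotoxicity

This account rests on a few compounds, and the source may have more. Where it says the series, first, only, none or still open, it means among the compounds named here.

Compound 1 `Cc1ccc(NC(=O)c2cccc(/C=C3\CC(=O)N(c4ccccc4)C3=O)c2)cc1` was tested in an ADME assay on NCM460 cells (Homo sapiens) for cytotoxicity, read by MTT assay, with a stated time of 72 h; a higher number here means a weaker inhibitor, a lower number a stronger inhibitor. In this assay compound 1 gives only a limit, > 100000 nM, so no actual number is known for it. Compound 2 `CCc1ccc(NC(=O)c2cccc(/C=C3\CC(=O)N(c4ccccc4)C3=O)c2)cc1` likewise returns only a limit in this assay, > 100000 nM. Compound 3 `CCc1cccc(NC(=O)c2cccc(/C=C3\CC(=O)N(Cc4ccccc4)C3=O)c2)c1` also returns only a limit in this assay, > 100000 nM. Among the measured compounds shown here, the single comparison between measured compounds, a step that the two limits leave unreadable from compound 1 to compound 2, therefore cannot be read, and all three results rest at the limit of > 100000 nM in this assay, at which 3 of the 3 values shown sit.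

Compound 4 `Cc1ccc(NC(=O)c2cccc(/C=C3\CC(=O)N(c4ccccc4)C3=O)c2)cc1C` differs from compound 1 in one place: methyl in place of hydrogen on an aromatic carbon. For the measured compounds named here, no measured step bears directly on this change, and the one measured step that exists is itself unreadable. The expectation for compound 4 is that it too shows no measurable effect in this assay, because compound 1 sits at the limit of > 100000 nM in this assay, at which 3 of the 3 values shown sit, and nothing seen so far moves away from it. Compound 4 is therefore estimated at 150000 nM, with a range from 50000 nM to 500000 nM. The expected step, a step that the limit leaves unreadable from compound 1 to compound 4, is none beyond the usual scatter.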

Compound 4, half-maximal inhibitory concentration: > 100000 nM
Compound 4: only a limit was reported (the forecaster's own chance of this, stated with the estimate: 85%); the middle value does not contradict the limit.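

The steps to compound 4 from compound 1 and from compound 2 cannot be read, because each pair offers only limits: the limit of > 100000 nM in this assay, at which 4 of the 4 values shown sit. The compounds shown leave open whether any change to the shared core would give an actual number in this assay.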